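The source may report more compounds than this note shows. Statements on the series, on what has been measured and on what is new or still open speak of the compounds shown alone.

Measured so far:
compound 1 `O=C(Nc1cccc(-n2cc(-c3ccncc3)c(-c3cc(O)cc(Cl)c3)n2)c1)Nc1ccc(Cl)c(C(F)(F)F)c1`, -10%
compound 2 `COc1cc(Cl)cc(-c2nn(-c3cccc(NC(=O)Nc4cc(C(F)(F)F)cc(C(F)(F)F)c4)c3)cc2-c2ccncc2)c1`, -22%

Both compounds were run in a functional assay on OVCAR-4 cells (Homo sapiens) for inhibition, read by sulforhodamine B assay, with a stated time of 48 h, tested at 100 uM; a higher number here means a weaker effect of the compound at the concentration tested, a lower number a stronger effect. Compound 1 gives -10% and compound 2 gives -22%. Going by the values given here, of the two numbers, compound 2 stands lowest; the gap to compound 1, its only neighbour, lies beyond the usual scatter of the read-out. Among the compounds with values here, no step between compounds that differ in one place has been measured, so nothing yet shows how a single change moves the activity read-out.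

Compound 3 `COc1cc(Cl)cc(-c2nn(-c3cccc(NC(=O)Nc4cccc(C(F)(F)F)c4)c3)cc2-c2ccncc2)c1` is not yet measured. It differs from compound 2 in one place: hydrogen in place of trifluoromethyl on an aromatic carbon. The group that leaves is a trifluoromethyl, the group that enters is a hydrogen, and the place is an aromatic carbon of a six-membered aromatic ring of carbon only, meta to a trifluoromethyl group.

Within the data shown here, with no measured step of this kind to lean on, the expected step from compound 2 to compound 3 is a number 10 percentage points higher from compound 2 to compound 3 (within the scatter) in this assay, that is, no change beyond the scatter, leaning if anything toward a higher number. For compound 3 the estimate in this assay is -12%, within -40% to 20%.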

Compound 3, a percentage reported as activity, at one concentration (the size of the read-out at that concentration, not a potency): -13%
Compound 3: the middle estimate sits 1 percentage points above what was measured, within the range that was stated.
By their numbers in this assay, from the lowest: compounds 2, 3 and 1 (each within the scatter of the next, the first and the last beyond it).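

In this assay, going by these compounds alone, the step of a number 9 percentage points higher from compound 2 to compound 3 (within the scatter) is the first single-place comparison, and it concerns an aromatic carbon of a six-membered aromatic ring of carbon only, meta to a trifluoromethyl group. At this position, the read-out does not separate trifluoromethyl from hydrogen: the group with its 4 heavy atoms can be exchanged for a hydrogen with a step that stays within the scatter, a statement that holds for this one pair only. Nothing measured on these compounds speaks to why the exchange has so small an effect on the read-out.

Going by these compounds, whether this tolerance extends to groups of another kind at the same carbon, such as an amine, a carboxylic acid or a nitrile, remains open, as does the effect of exchanging the remaining trifluoromethyl on the same ring. Compound 1 differs from compound 2 and compound 3 in more than one place, so the parts played by its hydroxyl and chlorine substituents cannot yet be read on their own.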